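The source may report more compounds than this note shows. Statements on the series, on what has been measured and on what is new or still open speak of the compounds shown alone.

Of the compounds shown here, three have been tested in a functional assay on QGY7701 cells (Homo sapiens) for cytotoxicity, read by MTT assay, with a stated time of 24 h (on this read-out higher numbers stand for weaker inhibition and lower numbers for stronger inhibition), and a fourth awaits its number. Compound 1 `C=CC1=C(C(=O)Nc2ccccc2OC)C(c2ccc(F)cc2)OC1` gives 52800 nM in this assay. Compound 2 `C=CC1=C(C(=O)Nc2ccccc2OC)C(c2ccc(Cl)c(Cl)c2)OC1` differs from compound 1 by a single change (3,4-dichlorophenyl in place of 4-fluorophenyl on a saturated ring carbon). For compound 2 this assay reports only a limit, > 100000 nM, rather than a number. The step is therefore an at least 1.8-fold higher number from compound 1 to compound 2 (0.27 log units; that floor lies within the scatter), which is all that can be said, given (the limit of > 100000 nM in this assay, at which 1 of the 3 values shown sits). Compound 3 `C=CC1=C(C(=O)NCc2ccccc2)C(c2ccc(F)cc2)OC1` differs from compound 1 at the other end of the shared core (benzyl in place of 2-methoxyphenyl on an amide-type nitrogen), and in this assay compound 3 gives 67600 nM, a step of a 1.3-fold higher number from compound 1 to compound 3 (0.11 log units; within the scatter) that does not separate the two compounds.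

Compound 4 `C=CC1=C(C(=O)NCc2ccccc2)C(c2ccc(Cl)c(Cl)c2)OC1` has not yet been measured. It differs from compound 3 in exactly the way compound 2 differs from compound 1 (3,4-dichlorophenyl in place of 4-fluorophenyl on a saturated ring carbon); the group leaves and enters at the same place in the shared core, so this is the same change. Its one measured occurrence, from compound 1 to compound 2, produced a step of at least an at least 1.8-fold higher number from compound 1 to compound 2 (0.27 log units; that floor lies within the scatter), and compound 3 already starts from 67600 nM. On that basis the step from compound 3 to compound 4 is expected to be about a 2.2-fold higher number from compound 3 to compound 4 (0.35 log units; beyond the scatter), with a real chance that only a limit is returned. Compound 4 is thus estimated at 150000 nM in this assay.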

Compound 4, half-maximal inhibitory concentration: > 100000 nM
Compound 4: a limit, no number; the forecaster's own chance of this, stated with the estimate: 70%; the middle value lies beyond the limit too.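

In this assay compound 4 returns only a limit, > 100000 nM, and not a number. Placing 3,4-dichlorophenyl where 4-fluorophenyl stood on the benzyl amide core therefore gives an at least 1.4-fold higher number from compound 3 to compound 4 (0.17 log units; that floor lies within the scatter), and the comparison with the first core can go only this far: the same change on two cores in this assay, an at least 1.8-fold higher number (0.27 log units; that floor lies within the scatter) from compound 1 to compound 2 and an at least 1.4-fold higher number (0.17 log units; that floor lies within the scatter) from compound 3 to compound 4; the limit leaves it open whether they differ What this shows is modest: on both cores the compound carrying 3,4-dichlorophenyl ends at a limit, so the two cases do not conflict, but neither floor lies beyond the scatter, so the data establish neither a real loss of activity on either core nor that the change has the same size on both, and the step from compound 2 to compound 4 cannot be read at all.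

The compounds shown leave open whether a group such as 4-chlorophenyl or 4-methoxyphenyl on that saturated ring carbon would give actual numbers on both cores, which would allow the size of such a change to be compared from one core to the other. They also leave open whether a longer chain such as phenylethyl on the amide nitrogen, or an amine or a carboxylic acid on its phenyl ring, would move the values away from this weak end of the read-out.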